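The source may hold more compounds than are shown below. What is called first, only, known or untested is meant among the compounds shown, and "the series" means these compounds.

Compound 1, `CN(C)C(=O)c1cc2cnc(Nc3ccc(S(=O)(=O)NCCCCN=C=S)cc3)nc2n1C1CCCC1`, is one of three compounds tested in a functional assay on NCI-H1299 cells (Homo sapiens) for inhibition, read by CCK-8 assay, with a stated time of 72 h, tested at 10 uM; on this read-out lower numbers stand for a weaker effect and higher numbers for a stronger effect at the one concentration tested; in this assay compound 1 gives 72.7%. On the numbers shown it stands second of the three. Its nearest neighbour is compound 2, `CN(C)C(=O)c1cc2cnc(Nc3ccc(S(=O)(=O)NCCCCCCN=C=S)cc3)nc2n1C1CCCC1`, which in this assay gives 70.6%; the difference is a number 2.1 percentage points lower from compound 1 to compound 2 (within the scatter). Furthest from it is compound 3, `CN(C)C(=O)c1cc2cnc(Nc3ccc(C(=O)NCCCCN=C=S)cc3F)nc2n1C1CCCC1`, which in this assay gives 78.9%, a higher reading that nonetheless lies within the scatter of compound 1.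

The next compound, compound 4, is `CN(C)C(=O)c1cc2cnc(Nc3ccc(NC(=O)CCCCCN=C=S)cc3)nc2n1C1CCCC1`. Against compound 1 the change is a group of 11 heavy atoms (7 carbon, 2 nitrogen, 1 oxygen, 1 sulfur; no ring) in place of a group of 11 heavy atoms (5 carbon, 2 nitrogen, 2 oxygen, 2 sulfur; no ring), on an aromatic carbon. Among the compounds with values here, only one measured step bears on this change: from compound 1 to compound 2 the chain between the sulfonamide nitrogen and the isothiocyanate was lengthened, and the effect was a number 2.1 percentage points lower from compound 1 to compound 2 (within the scatter). Within the data shown here, no measured step exchanges the sulfonamide for an amide on its own; compound 3 carries an amide but also a fluorine, so its reading cannot be separated into the two changes. Among the measured compounds shown here, with the one relevant step lying within the scatter, the step in this assay is expected to be a number 0.7 percentage points lower from compound 1 to compound 4 (within the scatter), with no direction beyond the scatter. Compound 4 is therefore estimated at 72%, between 58% and 84%.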

Compound 4, a percentage reported as inhibition, at one concentration (the size of the read-out at that concentration, not a potency): 85%
Compound 4: middle estimate off by 13 percentage points, on the low side; the measured number lies above the stated range.
By their numbers in this assay, from the lowest: compounds 2, 1, 3 and 4 (each within the scatter of the next, the first and the last beyond it).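

Replacing the whole group on this aromatic carbon, para to a large group, moved the reading in this assay by more than the chain lengthening had, which stayed within the scatter at a number 2.1 percentage points lower from compound 1 to compound 2 (within the scatter): the new change gave a number 12.3 percentage points higher from compound 1 to compound 4 (beyond the scatter). This is the first step among these compounds to lie beyond the scatter, so the group at this position can shift the inhibition measurably, whereas lengthening the chain on the sulfonamide did not. The group that leaves and the group that enters have the same count of heavy atoms and both end in the isothiocyanate, yet no measurement shown here explains why the reading differs.

The step changes the sulfonamide link, its direction and the chain together, so the compounds shown do not tell which of these carries the difference. Also open, going by these compounds, is how the amide-linked series would respond to a longer or shorter chain, or to a primary amine or an acetamide in place of the isothiocyanate at the chain end.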